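The source may report more compounds than this note shows. Statements on the series, on what has been measured and on what is new or still open speak of the compounds shown alone.

Measured so far:
compound 1 `CCCc1ccc(-c2cc(Cl)cc(C(=O)Nc3nn[nH]n3)n2)cc1`, 78%
compound 2 `CCCCc1ccc(-c2cc(Cl)cc(C(=O)Nc3nn[nH]n3)n2)cc1`, 0%
compound 3 `Nc1ccc(-c2cc(Cl)cc(C(=O)Nc3nn[nH]n3)n2)cc1`, 100%

In a functional assay on the whole organism with Rattus norvegicus as the target, at a dose of 1 mg/kg by the oral route (on this read-out lower numbers stand for a weaker effect and higher numbers for a stronger effect at the one dose given), compound 3 gives 100%, the highest of the three numbers: a number 22 percentage points higher from compound 1 to compound 3 (beyond the scatter) and a number 100 percentage points higher from compound 2 to compound 3 (beyond the scatter), both beyond the scatter. Compound 4 `Nc1ccc(-c2cccc(C(=O)Nc3nn[nH]n3)n2)cc1` is the next step from compound 3: hydrogen in place of chloro on an aromatic carbon. Within the data shown here, no measured step touches this position; the three recorded steps, including a number 78 percentage points lower from compound 1 to compound 2 (beyond the scatter), all concern the substituent on the phenyl ring and give no direction for a chloro-to-hydrogen change. The rest of compound 3, with its 4-aminophenyl group, is kept. A step of a number 20 percentage points lower from compound 3 to compound 4 (beyond the scatter) is expected, with a wide range allowed. The estimated value for compound 4 is 80%, range 35% to 100%.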

Compound 4, a percentage reported as inhibition, in the whole organism at one dose (the size of the read-out at that dose, not a potency): 62%
Compound 4: the middle estimate sits 18 percentage points above what was measured, within the range that was stated.
By their numbers in this assay, from the lowest: compound 2; then compound 4; then compound 1; then compound 3.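

In this assay, hydrogen in place of chloro opposite the ring nitrogen gives a number 38 percentage points lower from compound 3 to compound 4 (beyond the scatter) and is a large step beyond the scatter. Among these compounds, this shows that the position, untouched by the earlier steps, affects the read-out at the one dose given when the 4-aminophenyl group is kept. Nothing available here accounts for the drop.

On these data alone, whether fluoro, bromo or methyl at this position would match chloro stays open. So does whether removing chloro has a step of similar size with the propyl group of compound 1 in place of the amino group.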